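The source may hold more compounds than are shown below. What is called first, only, known or untested is meant among the compounds shown, and "the series" means these compounds.

Compound 1 `Cn1cc(C2CC(c3ccc(Cl)cc3)=NN2C(=O)c2cccnc2)c2cc(Br)ccc21` and compound 2 `Cn1cc(C2CC(c3ccc(Br)cc3)=NN2C(=O)c2cccnc2)c2cc(Br)ccc21` share one core; compound 3 `COc1ccc2c(c1)c(C1CC(c3ccc(Cl)cc3)=NN1C(=O)c1ccc(OC)nc1)cn2C` and compound 4 `COc1ccc2c(c1)c(C1CC(c3ccc(Br)cc3)=NN1C(=O)c1ccc(OC)nc1)cn2C` share another, and the difference between the two cores is not broken down here. In a functional assay on A549 cells (Homo sapiens) for inhibition, read by MTT assay, with a stated time of 48 h (a lower number here means a stronger inhibitor of growth, a higher number a weaker inhibitor of growth), compound 1 gives 7650 nM. For compound 2 the this assay reports only a limit, > 10000 nM. The change bromo in place of chloro on an aromatic carbon thus gave an at least 1.3-fold higher number from compound 1 to compound 2 (0.11 log units; that floor lies within the scatter), a step that runs into (the limit of > 10000 nM in this assay, at which 1 of the 3 values shown sits). In the this assay compound 3 gives 3390 nM, the lowest of the two numbers. The change to compound 4 is the same change, (bromo in place of chloro on an aromatic carbon), at the same place. For compound 4 a step of similar size is expected, a 1.6-fold higher number from compound 3 to compound 4 (0.21 log units; within the scatter), resting on the outcome of an at least 1.3-fold higher number from compound 1 to compound 2 (0.11 log units; that floor lies within the scatter), where the bromo compound gave the weaker result. Compound 4 is therefore estimated at 5500 nM, within 2500 nM to 12000 nM.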

Compound 4, concentration for 50% growth inhibition: > 10000 nM
Compound 4 was reported as a limit (the forecaster's own chance of this, stated with the estimate: 20%); at least 1.8-fold (0.25 log units) between middle value and limit.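

In this assay, 4-chlorophenyl to 4-bromophenyl gives an at least 2.9-fold higher number from compound 3 to compound 4 (0.46 log units; beyond the scatter). Among the compounds shown here, on both cores the step points towards a higher number, but only this step is beyond the scatter, so the direction carries over with firm support on one core alone. The values of compound 2 and compound 4 are both limits, so the full size of the change is unknown on either core and no difference between the cores can be claimed: the same change on two cores in this assay, an at least 1.3-fold higher number (0.11 log units; that floor lies within the scatter) from compound 1 to compound 2 and an at least 2.9-fold higher number (0.46 log units; beyond the scatter) from compound 3 to compound 4; the limit leaves it open whether they differ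

The compounds shown leave open how fluoro, an amine or a carboxylic acid would read in place of the chloro group. The contribution of the two cores themselves also remains unresolved.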